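A few compounds are considered here, and "the series" means these few. Any claim that something is new, unique, unknown or untested is made for them only; others in the source may bear on it.

Two measured compounds share one core and differ only in the aromatic group attached to the amide carbonyl. Compound 1 `CC(C)(CNC(=O)c1ccccc1O)CC1=C(O)C(=O)c2ccccc2C1=O` carries a 2-hydroxyphenyl there, and compound 2 `CC(C)(CNC(=O)c1ccc2ccccc2c1)CC1=C(O)C(=O)c2ccccc2C1=O` a naphthalen-2-yl. In an ADME assay on Vero cells (Chlorocebus sabaeus) for cytotoxicity, read by fluorescence, with a stated time of 4 days (a higher number here means a weaker inhibitor, a lower number a stronger inhibitor), compound 1 gives 32100 nM, and in this assay compound 2 gives 46700 nM. The step of a 1.5-fold higher number from compound 1 to compound 2 (0.16 log units; within the scatter) shows that these two numbers cannot be told apart; on the two numbers available, compound 2 is not distinguishable from compound 1.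

Compound 3 `CC(C)(CNC(=O)c1ccc2ccccc2c1O)CC1=C(O)C(=O)c2ccccc2C1=O` is next: hydroxy in place of hydrogen on an aromatic carbon. Its aromatic group thus combines the fused two-ring system of compound 2 with a hydroxy of the kind present in compound 1. Going by the values given here, the only measured step that bears on this change is the one from compound 1 to compound 2, which exchanged the whole group and stayed within the scatter. No step beyond the scatter is therefore expected for adding the hydroxy alone, and the expected step is a 1.2-fold lower number from compound 2 to compound 3 (0.09 log units; within the scatter). Compound 3 is estimated at 38000 nM in this assay, with a range from 15000 nM to 95000 nM.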

Compound 3, half-maximal inhibitory concentration: 93700 nM
Compound 3: the middle estimate sits 2.5-fold (0.39 log units) below what was measured; the measured number falls inside the stated range.
By their numbers in this assay, from the lowest: compounds 1, 2 and 3 (each within the scatter of the next, the first and the last beyond it).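

Going by these compounds alone, the step of a 2.0-fold higher number from compound 2 to compound 3 (0.30 log units; within the scatter) in this assay is the first reading of a single hydroxy on its own, since the earlier step exchanged the whole aromatic group. On this carbon of the fused two-ring system, ortho to a large group and ortho to a fused ring, replacing hydrogen with hydroxy does not give a change that can be separated from the ordinary variation between repeated measurements, so compound 2 and compound 3 cannot be told apart here. No measurement available here accounts for this result or links it to any property of the hydroxy.

One pair of compounds cannot show whether this carbon tolerates other groups, so a methoxy, an amine or a carboxylic acid in the same place could still give a step beyond the scatter. As far as these compounds go, it also remains open whether a hydroxy on another carbon of the fused two-ring system would give a similarly small step, or a clearly larger one.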